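Removing One Methoxy Group: From Compound 2 to Compound 4

The source may hold more compounds than are shown below. What is called first, only, known or untested is meant among the compounds shown, and "the series" means these compounds.

Of the compounds shown here, three have been measured in a functional assay on HepG2 cells (Homo sapiens) for inhibition, read by MTT assay, with a stated time of 48 h; a higher number here means a weaker inhibitor, a lower number a stronger inhibitor. Compound 1 `COc1cc(C(=O)/C=C/c2ccc(N(C)C)cc2)cc(OC)c1OC` gives 30000 nM. For the measured compounds named here, compound 3 `COc1cc(C(=O)/C=C/c2ccc(O)cc2)cc(OC)c1OC` gives 16000 nM, and the step of a 1.9-fold lower number from compound 1 to compound 3 (0.27 log units; within the scatter) is the only single-point change measured so far. Compound 2 `COc1cc(OC)c(OC)cc1/C=C/C(=O)c1cc(OC)c(OC)c(OC)c1` gives 16100 nM; its number sits between those of compound 1 and compound 3, but both gaps lie within the scatter, so the three compounds cannot be separated on this assay. Compound 4 `COc1ccc(/C=C/C(=O)c2cc(OC)c(OC)c(OC)c2)c(OC)c1` differs from compound 2 by hydrogen in place of methoxy on an aromatic carbon. Going by the values given here, no measured step removes a methoxy group; the one measured step swaps hydroxy for dimethylamino on an aromatic carbon and stayed within the scatter, so it offers only a loose guide. With no step beyond the scatter anywhere among these three compounds, the expected outcome is a 1.0-fold lower number from compound 2 to compound 4 (0.00 log units; within the scatter), no step beyond the scatter. Compound 4 is therefore estimated at 16000 nM, with a range from 6000 nM to 45000 nM.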

Compound 4, half-maximal inhibitory concentration: > 100000 nM
Compound 4 ended at the assay's limit; the forecaster's own chance of this, stated with the estimate: 10%; middle value at least 6.2-fold (0.79 log units) away from the limit.
By their numbers in this assay, from the lowest: compounds 3, 2 and 1 (each within the scatter of the next). At a limit, above all of these: compound 4.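

Hydrogen in place of this methoxy group, which stands ortho to a methoxy group and para to a methoxy group, gives an at least 6.2-fold higher number from compound 2 to compound 4 (0.79 log units; beyond the scatter) in this assay. This is the first step among these compounds to lie beyond the scatter, whereas the only earlier one, a 1.9-fold lower number from compound 1 to compound 3 (0.27 log units; within the scatter), stayed within it, so this position responds to a single change in a way the earlier compounds did not show. Compound 4 gives > 100000 nM, which is a limit and not a number, and it stands alone there: the limit of > 100000 nM in this assay, at which 1 of the 4 values shown sits.

The compounds shown leave open how large the step really is. They also leave open whether an ethoxy group or a fluorine atom at this position would keep the number close to that of compound 2, and whether the other methoxy groups on this ring matter as much.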